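Swapping phenyl for hydroxymethyl: what dose to expect

The source may report more compounds than this note shows. Statements on the series, on what has been measured and on what is new or still open speak of the compounds shown alone.

Measured in a functional assay on the whole organism with Rattus norvegicus as the target; a higher number here means that more compound is needed for the effect, a lower number that less compound is needed:
- compound 1 `CCOCCOC(=O)C(=O)Nc1nc(-c2cc(COC)no2)cs1`: 2.4 mg/kg
- compound 2 `CCOCCOC(=O)C(=O)Nc1nc(-c2cc(C)on2)cs1`: 1.3 mg/kg
- compound 3 `CCOCCOC(=O)C(=O)Nc1nc(-c2cc(-c3ccccc3)on2)cs1`: 0.2 mg/kg

Of these three, compound 3 has the lowest number, 0.2 mg/kg, and the gaps to both others lie beyond the usual scatter. The next compound, compound 4 `CCOCCOC(=O)C(=O)Nc1nc(-c2cc(CO)on2)cs1`, carries hydroxymethyl in place of phenyl on an aromatic carbon. Going by the values given here, two measured steps bear on this change. The closer one is a 6.5-fold lower number from compound 2 to compound 3 (0.81 log units; beyond the scatter), which came with phenyl in place of methyl at that same carbon. Compound 4 loses the phenyl again, so that step can be read in reverse, with hydroxymethyl standing in for methyl. The other is a 1.8-fold lower number from compound 1 to compound 2 (0.27 log units; within the scatter), which came with 5-methyl-1,2-oxazol-3-yl in place of 3-(methoxymethyl)-1,2-oxazol-5-yl. It changes more than one feature, so it offers only a weak hint that a side chain with oxygen need not shift the number much. A rise of similar size to the first step is therefore expected in this assay, and the estimated change is a 7.5-fold higher number from compound 3 to compound 4 (0.88 log units; beyond the scatter). Compound 4 is estimated at 1.5 mg/kg, with an expected range from 0.5 mg/kg to 4 mg/kg.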

Compound 4, dose for half-maximal effect: 1.8 mg/kg
Compound 4: the middle estimate sits 1.2-fold (0.08 log units) below what was measured; the range from low to high includes it.
By their numbers in this assay, from the lowest: compound 3; then compounds 2, 4 and 1 (each within the scatter of the next).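

In this assay, hydroxymethyl in place of phenyl gives a 9.0-fold higher number from compound 3 to compound 4 (0.95 log units; beyond the scatter) at this carbon next to the ring oxygen, so the low number of compound 3 is not matched by either non-ring group tried here. Adding hydroxy to the methyl side chain gives a 1.4-fold higher number from compound 2 to compound 4 (0.14 log units; within the scatter) and leaves no readable difference, and replacing 3-(methoxymethyl)-1,2-oxazol-5-yl with 5-(hydroxymethyl)-1,2-oxazol-3-yl gives a 1.3-fold lower number from compound 1 to compound 4 (0.12 log units; within the scatter) and also stays within the scatter. Nothing available here accounts for the gap between phenyl and hydroxymethyl.

From the compounds shown here alone, it remains open whether the low number requires an aromatic ring at this carbon, as a pyridyl or benzyl group could help to show. Aminomethyl, a carboxylic acid or a longer chain such as butyl might also behave like hydroxymethyl or differently.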